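A few compounds are considered here, and "the series" means these few. Any claim that something is new, unique, unknown or untested is made for them only; others in the source may bear on it.

Measured so far in a functional assay on MCF7 cells (Homo sapiens) for antiproliferative activity, read by MTT assay, with a stated time of 48 h; on this read-out higher numbers stand for weaker inhibition and lower numbers for stronger inhibition:
- compound 1 `Cc1ccc(-c2cc(NC(=O)/C=C/c3ccc(Br)cc3)n[nH]2)cc1` gives 1370 nM
- compound 2 `O=C(/C=C/c1ccc(Br)cc1)Nc1cc(-c2ccc(Br)cc2)[nH]n1` gives 920 nM

Compound 1 gives the highest of the two numbers in this assay; its nearest neighbour is compound 2, at a distance of a 1.5-fold lower number from compound 1 to compound 2 (0.17 log units; within the scatter), a difference that stays within the scatter. The unmeasured compound 3 `Cc1ccc(-c2cc(NC(=O)/C=C/c3ccc(F)cc3)n[nH]2)cc1` differs from compound 1 at the other end of the molecule: fluoro in place of bromo on an aromatic carbon.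

Among the measured compounds shown here, the single measured step concerns a bromo in place of methyl on the aryl attached to the core, not the bromo on the cinnamoyl side, so no measured step bears directly on the change to compound 3. The one step shown was within the scatter, which gives no reason to expect a large move. The expectation for compound 3 is therefore a step of a 1.3-fold higher number from compound 1 to compound 3 (0.12 log units; within the scatter), within the scatter in either direction. Compound 3 is estimated at 1800 nM, with a range from 700 nM to 4500 nM.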

Compound 3, half-maximal inhibitory concentration: 950 nM
Compound 3: middle estimate off by 1.9-fold (0.28 log units), on the high side; low and high end bracket the measured number.
By their numbers in this assay, from the lowest: compounds 2, 3 and 1 (each within the scatter of the next).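

In this assay, among the compounds shown here, the change from 4-bromophenyl to 4-fluorophenyl gives a 1.4-fold lower number from compound 1 to compound 3 (0.16 log units; within the scatter), the first measured step at this end of the molecule, and it stays within the scatter. The earlier step on the aryl at the other end, a 1.5-fold lower number from compound 1 to compound 2 (0.17 log units; within the scatter), is also within the scatter, so neither single-group swap shown has moved the number beyond it. No measurement given here offers an explanation for this step.

From the compounds shown here alone, it remains open whether a different kind of group at this place, such as an amine, a methoxy group or a carboxylic acid, would move the number beyond the scatter. Going by these compounds, it is also open whether the fluoro group would give a similar result on a compound carrying bromo instead of methyl on the other aryl.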